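This account rests on a few compounds, and the source may have more. Where it says the series, first, only, none or still open, it means among the compounds named here.

Working notes on the series in a functional assay (aorta) with Oryctolagus cuniculus as the target; on this read-out higher numbers stand for weaker inhibition and lower numbers for stronger inhibition.

Compound 1 `Nc1ccnc(-c2nn(Cc3ccccc3F)c3ncccc23)n1` is recorded twice in this assay, at 270 nM; 265000 nM (2 entries); the two entries of compound 1, (the several entries of compound 1 in this assay, 270 nM; 265000 nM (2 entries)), lie far apart, so that compound serves as a caution rather than a fixed point. Compound 2 `CCCCCc1cnc(-c2nn(Cc3ccccc3F)c3ncccc23)nc1N` gives 200000 nM in this assay. Compound 3 `CCCCCCc1cnc(-c2nn(Cc3ccccc3F)c3ncccc23)nc1N` gives 1040000 nM, the highest of the two single numbers in this assay; the step of a 5.2-fold higher number from compound 2 to compound 3 (0.72 log units; beyond the scatter), a methyl in place of hydrogen on a saturated chain carbon, five bonds along the chain from an aromatic carbon, is modest but beyond the scatter.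

Compound 4 `Nc1nc(-c2nn(Cc3ccccc3F)c3ncccc23)ncc1C1CCC1` differs from compound 3 by cyclobutyl in place of hexyl on an aromatic carbon. Within the data shown here, only the step from compound 2 to compound 3 bears on it, and only loosely: lengthening the chain raised the number there, and the cyclobutyl that enters is the smaller group. The expected step of a 3.5-fold lower number from compound 3 to compound 4 (0.54 log units; beyond the scatter) is therefore downward, of roughly the size seen from compound 2 to compound 3, with wide uncertainty. Compound 4 is estimated at 300000 nM in this assay, within 60000 nM to 1500000 nM.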

Compound 4, half-maximal inhibitory concentration: 633000 nM
For compound 4 the middle estimate is 2.1-fold (0.32 log units) below the measured one, and the stated range covers the measured number.
By their numbers in this assay, from the lowest: compound 2; then compounds 4 and 3 (each within the scatter of the next).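

In this assay, this position, on an aromatic carbon ortho to an amino group, now carries a ring as well as open chains, and the step of a 1.6-fold lower number from compound 3 to compound 4 (0.22 log units; within the scatter) shows no separation between cyclobutyl and hexyl. The step of a 3.2-fold higher number from compound 2 to compound 4 (0.50 log units; beyond the scatter) is the firmer reading: compound 4 parts from the pentyl compound, although only the hexyl compound had done so before. Cyclobutyl has 4 heavy atoms against 6 in hexyl, yet that smaller count does not bring compound 4 to the number of compound 2, so heavy-atom count alone does not order these three compounds.

From the compounds shown here alone, whether a shorter chain such as propyl, or a ring carrying an amine or a hydroxyl group, would behave differently stays open. The comparison with the compound lacking any group here offers no firm baseline: the several entries of compound 1 in this assay, 270 nM; 265000 nM (2 entries)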